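The source may hold more compounds than are shown below. What is called first, only, known or untested is meant among the compounds shown, and "the series" means these compounds.

Three compounds have numbers in an assay on NIH3T3 cells for inhibition of Sonic hedgehog protein (Mus musculus), read by a luciferase reporter, with a stated time of 48 h; a lower number here means a stronger inhibitor, a higher number a weaker inhibitor. Compound 1, `Cc1ccccc1C(=O)Nc1ccc(Nc2ncc(C)c(-c3ccc(OC(F)(F)F)cc3)n2)cc1`, gives 42.1 nM in this assay, the highest of the three numbers. Compound 2, `Cc1cnc(Nc2ccc(C(=O)Nc3c(C)cccc3C)cc2)nc1-c1ccoc1`, gives 15.7 nM in this assay, a lower number than compound 1 and beyond the scatter. Compound 3, `Cc1cccc(C)c1NC(=O)c1ccc(Nc2ncc(C3CC3)c(-c3ccc(OC(F)(F)F)cc3)n2)cc1`, gives 1.3 nM in this assay, the lowest of the three and well beyond the scatter from compound 1. No two of these compounds differ in one place only, so no single-step comparison can be drawn among them.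

Compound 4, `Cc1cnc(Nc2ccc(C(=O)NC3CCCCC3)cc2)nc1-c1ccc(OC(F)(F)F)cc1`, has not yet been measured. It differs from compound 1 by cyclohexylcarbamoyl in place of ((2-methylphenyl)carbonyl)amino on an aromatic carbon. Among the measured compounds shown here, no measured pair mirrors this change, so the direction and size of the step can only be guessed. Since the two measured compounds that carry a carbamoyl group on the aromatic carbon, compound 2 with 15.7 nM and compound 3 with 1.3 nM, both give lower numbers than compound 1, a modest step toward a lower number is expected, about a 2.1-fold lower number from compound 1 to compound 4 (0.32 log units; beyond the scatter). Compound 4 is therefore expected to give about 20 nM in this assay, with a range from 5 nM to 80 nM.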

Compound 4, half-maximal inhibitory concentration: 2.2 nM
Estimate against measurement, compound 4: 9.1-fold (0.96 log units) above, outside the stated range (below it).
By their numbers in this assay, from the lowest: compounds 3 and 4 (each within the scatter of the next); then compound 2; then compound 1.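

In this assay, cyclohexylcarbamoyl in place of ((2-methylphenyl)carbonyl)amino on this aromatic carbon gives a large step, a 19-fold lower number from compound 1 to compound 4 (1.28 log units; beyond the scatter), the first single-place comparison available among these compounds. It shows that the number depends strongly on the group at this position, and that a six-membered non-aromatic ring of carbon only can stand where compound 1 carries a six-membered aromatic ring of carbon only, with a much lower number as the result. No measurement here accounts for the size of this step.

The ring and the direction of the amide change together in this one step, and the compounds shown do not separate the two. Also open, from the compounds shown here alone, is how the number would respond to an amine or a hydroxyl on the cyclohexyl ring, or to a straight hexyl chain in its place.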